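The source may report more compounds than this note shows. Statements on the series, on what has been measured and on what is new or still open speak of the compounds shown alone.

In an ADME assay on cells (Hepatocyte, Rattus norvegicus) for metabolic stability (a higher number here means that the compound lasts longer, a lower number that the compound disappears faster), compound 2 `CC(=O)N1CCC(C(=O)N2N=CC[C@H]2c2ccccc2)CC1` gives > 3.11 h, which is a limit of the assay and not a number. Compound 1 `O=C(C1CCN(c2ccncn2)CC1)N1N=CC[C@H]1c1ccccc1` gives < 0.4 h, likewise a limit. Compound 3 `O=C(C1CCN(c2ccccn2)CC1)N1N=CC[C@H]1c1ccccc1` differs from compound 2 as follows: pyridin-2-yl in place of acetyl on an amine nitrogen in a ring. It has pyridin-2-yl in place of acetyl on an amine nitrogen in a ring. Within the data shown here, the one measured step, an at least 7.7-fold higher number from compound 1 to compound 2 (0.89 log units; beyond the scatter), bears on this: it lies beyond the scatter and put acetyl in place of pyrimidin-4-yl, and compound 3 reverses that kind of swap. A large fall is therefore expected, with the estimated step being an at least 10-fold lower number from compound 2 to compound 3 (1.01 log units; beyond the scatter). Compound 3 is expected at 0.3 h, within an estimated range of 0.1 h to 0.9 h.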

Compound 3, half-life: 0.0633 h
The estimate for compound 3 lay 4.7-fold (0.68 log units) above the measured number; measured number outside the range, below it.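

Placed on the amine nitrogen in the ring of the shared core in this assay, pyridin-2-yl in place of acetyl gives an at least 49-fold lower number from compound 2 to compound 3 (1.69 log units; beyond the scatter). Compound 3 thus falls on the same side of compound 2 as compound 1, so the drop seen with pyrimidin-4-yl is not confined to that one aromatic ring. The step between compound 1 and compound 3 cannot be read: the limit of < 0.4 h in this assay, at which 1 of the 3 values shown sits.

From the compounds shown here alone, it remains open whether a longer acyl chain such as propanoyl, or a methanesulfonyl group, at this nitrogen would keep the number as high as acetyl does.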